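The source may report more compounds than this note shows. Statements on the series, on what has been measured and on what is new or still open speak of the compounds shown alone.

Among the measured compounds shown here, in an assay on isolated protein for inhibition of alpha-ketoglutarate-dependent dioxygenase alkB homolog 3 (Homo sapiens), read by polymerase chain reaction, with a stated time of 1 h (on this read-out higher numbers stand for weaker inhibition and lower numbers for stronger inhibition), compound 2 `Cc1ccc2[nH]c(-n3[nH]c(C)c(Cc4ccc(C(F)(F)F)cc4)c3=O)nc2c1` gives 570 nM, the only number among the two values shown. Compound 1 `Cc1[nH]n(-c2ncccn2)c(=O)c1C` gives > 10000 nM, which is a limit of the assay rather than a number, as noted in the limit of > 10000 nM in this assay, at which 1 of the 2 values shown sits. Compound 3 `Cc1ccc2[nH]c(-n3[nH]c(C)c(Cc4ccc(Cl)cc4)c3=O)nc2c1` differs from compound 2 by chloro in place of trifluoromethyl on an aromatic carbon. For the measured compounds named here, no step between two measured compounds of this kind is available, so no direction is fixed by measurement, and the change is expected to stay within the usual scatter or cost a little potency. For compound 3 the estimate in this assay is 750 nM, ranging from 250 nM to 2500 nM, meaning an expected step of a 1.3-fold higher number from compound 2 to compound 3 (0.12 log units; within the scatter).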

Compound 3, half-maximal inhibitory concentration: 750 nM
Beside the measured number, compound 3's estimate shows no gap at the digits printed, within the range that was stated.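

Chloro in place of trifluoromethyl on this aromatic carbon, para to a large group, gives the first measured step in the series: a 1.3-fold higher number from compound 2 to compound 3 (0.12 log units; within the scatter). At this position, then, the four heavy atoms of trifluoromethyl can give way to the single atom of chloro with the reading staying within the scatter. Nothing measured here bears on why the two groups read alike.

Open, going by these compounds, is whether an amine, a carboxylic acid or a methoxy group on this carbon would hold the reading. Also open, on these data alone, is what plain hydrogen there would give.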